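From amino to 1H-pyrrol-1-yl on compound 3

The source may report more compounds than this note shows. Statements on the series, on what has been measured and on what is new or still open speak of the compounds shown alone.

Compound 1 `COc1cc(-c2noc(C(F)(F)F)n2)ccc1OCCCc1cc(C(=O)N(C)C)no1` gives 68000 nM
Compound 2 `CN(C)C(=O)c1cc(CCCOc2ccc(-c3noc(C(F)(F)F)n3)cc2C(F)(F)F)on1` gives 19200 nM
Compound 3 `CN(C)C(=O)c1cc(CCCOc2ccc(-c3noc(C(F)(F)F)n3)cc2N)on1` gives 90800 nM

All three numbers come from an ADME assay on HeLa cells (Homo sapiens) for cytotoxicity, read by crystal violet staining, with a stated time of 72 h (on this read-out lower numbers stand for higher toxicity in this test and higher numbers for lower toxicity in this test), and the compounds differ in one group on the shared core. Compound 3 sits at the high end of this small set, level with one neighbour within the scatter (a 1.3-fold higher number from compound 1 to compound 3 (0.13 log units; within the scatter)) and clearly apart from the other (a 4.7-fold higher number from compound 2 to compound 3 (0.67 log units; beyond the scatter)). Compound 4 `CN(C)C(=O)c1cc(CCCOc2ccc(-c3noc(C(F)(F)F)n3)cc2-n2cccc2)on1` has not been measured yet. It carries 1H-pyrrol-1-yl in place of amino on the same aromatic carbon (1H-pyrrol-1-yl in place of amino on an aromatic carbon). Within the data shown here, no measured compound has a ring at that place, so the guide is loose. The nearest evidence is the swaps among the three groups tested there, and the largest steps were modest (a 3.5-fold lower number from compound 1 to compound 2 (0.55 log units; beyond the scatter)). No group tested in place of amino gave a number higher beyond the scatter. The step expected in this assay is therefore a modest one towards a lower number (a 2.6-fold lower number from compound 3 to compound 4 (0.41 log units; beyond the scatter)). For compound 4 the estimated value is 35000 nM (expected range 10000 nM to 90000 nM).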

Compound 4, half-maximal cytotoxic concentration: 21200 nM
For compound 4 the middle estimate is 1.7-fold (0.22 log units) above the measured one; low and high end bracket the measured number.
By their numbers in this assay, from the lowest: compounds 2 and 4 (each within the scatter of the next); then compounds 1 and 3 (each within the scatter of the next).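

A ring on this aromatic carbon, 1H-pyrrol-1-yl, falls at the low end of the numbers in this assay: the swap from amino gives a 4.3-fold lower number from compound 3 to compound 4 (0.63 log units; beyond the scatter) and the swap from methoxy gives a 3.2-fold lower number from compound 1 to compound 4 (0.51 log units; beyond the scatter) in the same direction. Against trifluoromethyl it stands level, with a 1.1-fold higher number from compound 2 to compound 4 (0.04 log units; within the scatter) inside the scatter, so a ring and a group without a ring share the low end of this set while amino and methoxy share the high end. No measurement shown gives a reason for this split.

Still open, as far as these compounds go, is whether the lower number goes with rings in general or with this ring alone, as a phenyl or a saturated pyrrolidine ring at this place could show. Also open, from the compounds shown here alone, is whether a hydroxyl or a dimethylamino group would join amino and methoxy at the high end.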